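Shortening the alkenyl chain of compound 2

The compounds below may be only part of what the source reports. "The series", "measured", "known", "first", "only" and "open" are said of these compounds alone.

In a functional assay on HeLa cells (Homo sapiens) for antiproliferative activity, read by XTT assay, with a stated time of 72 h (on this read-out lower numbers stand for stronger inhibition and higher numbers for weaker inhibition), compound 1 `C=C(C)CC[C@]1(C)C2=CCC[C@](C)(C[C@H](O)c3ccoc3)[C@H]2CC[C@H]1C` gives 30200 nM, while compound 2 `C=C(C)CCC[C@]1(C)C2=CCC[C@](C)(C[C@@H](O)C3=CC(=O)OC3O)[C@H]2CC[C@H]1C` gives 2600 nM, the lower of the two numbers and so the stronger inhibition. Compound 3 `C=C(C)CC[C@]1(C)C2=CCC[C@](C)(C[C@@H](O)C3=CC(=O)OC3O)[C@H]2CC[C@H]1C` has not yet been measured. It differs from compound 2 in one place: 1-methylethenyl in place of 2-methylprop-2-en-1-yl on a saturated chain carbon, two bonds along the chain from a saturated ring carbon, with 1-methylethenyl in place of 2-methylprop-2-en-1-yl on a saturated chain carbon, two bonds along the chain from a saturated ring carbon. Within the data shown here, no measured pair isolates this change, so compound 2 at 2600 nM is the reference. The expected change is within the scatter, with no firm direction, an estimated 1.1-fold higher number from compound 2 to compound 3 (0.03 log units; within the scatter). For compound 3 the estimated value is 2800 nM, with an expected range of 1100 nM to 7000 nM.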

Compound 3, half-maximal inhibitory concentration: 5400 nM
Compound 3: middle estimate off by 1.9-fold (0.29 log units), on the low side; low and high end bracket the measured number.
By their numbers in this assay, from the lowest: compound 2; then compound 3; then compound 1.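

In this assay, the chain at this saturated carbon turns out to count: the shorter 1-methylethenyl in place of 2-methylprop-2-en-1-yl gives a 2.1-fold higher number from compound 2 to compound 3 (0.32 log units; beyond the scatter), a modest step beyond the scatter. Among these compounds, with the chain now held the same, the non-aromatic five-membered ring group in place of the aromatic one gives a 5.6-fold lower number from compound 1 to compound 3 (0.75 log units; beyond the scatter), the first reading of that exchange on its own. No measurement available bears on the cause of either step. Going by these compounds, whether a longer chain than 2-methylprop-2-en-1-yl, or a carboxylic acid in its place, would give a lower number stays open.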